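This account rests on a few compounds, and the source may have more. Where it says the series, first, only, none or still open, it means among the compounds named here.

Measured so far in an ADME assay on HEK293 cells (Homo sapiens) for cytotoxicity, read by fluorescence and resazurin assay, with a stated time of 24 h; on this read-out lower numbers stand for higher toxicity in this test and higher numbers for lower toxicity in this test:
compound 1 `CC(=O)Nc1ccc(-c2nnc(SC3=CS(=O)(=O)c4ccccc43)o2)cc1`, 4000 nM
compound 2 `O=S1(=O)C=C(Sc2nnc(-c3ccccn3)o2)c2ccccc21`, 5000 nM
compound 3 `O=S1(=O)C=C(Sc2nnc(-c3ccccc3Cl)o2)c2ccccc21`, 4000 nM

Compound 1 stands level with compound 3 at the digits given, and the two together hold the lowest numbers of the three; compound 2 sits only a little higher, and every gap among the three lies within the scatter of this kind of measurement. For the measured compounds named here, the one step that has been measured, a 1.3-fold lower number from compound 2 to compound 3 (0.10 log units; within the scatter), shows that exchanging the aromatic group on the far side of the shared core leaves the read-out essentially unmoved.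

Compound 4 `COc1ccc(-c2nnc(SC3=CS(=O)(=O)c4ccccc43)o2)cc1` is not yet measured. It differs from compound 1 in one place: methoxy in place of acetamido on an aromatic carbon. Going by the values given here, no measured pair exchanges these two groups, so the only guidance is the general quietness of this series, where even the change from compound 2 to compound 3 did not exceed the scatter. On that basis compound 4 is expected to stay where compound 1 stands, with no change at the digits printed from compound 1 to compound 4 (within the scatter) amounting to no step beyond the scatter. Compound 4 is estimated at 4000 nM, within a range from 2000 nM to 8000 nM.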

Compound 4, half-maximal cytotoxic concentration: 2000 nM
For compound 4 the middle estimate is 2.0-fold (0.30 log units) above the measured one, within the range that was stated.
By their numbers in this assay, from the lowest: compounds 4, 1, 3 and 2 (each within the scatter of the next, the first and the last beyond it).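

In this assay, the aromatic carbon para to a large group accepts methoxy in place of acetamido with a 2.0-fold lower number from compound 1 to compound 4 (0.30 log units; within the scatter), so this exchange, which removes the amide hydrogen, does not move the read-out beyond the scatter. Comparing the whole aromatic group gives a 2.0-fold lower number from compound 3 to compound 4 (0.30 log units; within the scatter), also within the scatter, whereas a 2.5-fold lower number from compound 2 to compound 4 (0.40 log units; beyond the scatter) is the first step in this set to pass beyond it, and only modestly. No measurement shown here accounts for that step.

The compounds shown leave open how an amine, a carboxylic acid or a longer alkoxy chain would read on this aromatic carbon. They also leave open whether methoxy would give a similar number on a pyridine ring.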